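Acetamido for acetoxy: expected tolerance of compound 4

This account rests on a few compounds, and the source may have more. Where it says the series, first, only, none or still open, it means among the compounds named here.

Compound 1 `O=CCc1c(-c2ccccc2Cl)c2cc(Cl)ccc2[nH]c1=O`: 120000 nM
Compound 2 `N#CCC(=O)OCCc1c(-c2ccccc2Cl)c2cc(Cl)ccc2[nH]c1=O`: 100000 nM
Compound 3 `CC(=O)OCC(=O)OCCc1c(-c2ccccc2Cl)c2cc(Cl)ccc2[nH]c1=O`: 100000 nM

All three compounds were measured in an ADME assay on HepG2 2.2.15 cells (Homo sapiens) for cytotoxicity; a lower number here means that less compound is tolerated, a higher number that more compound is tolerated. Compound 3 gives 100000 nM, level with compound 2, and the gap to compound 1 is small: a 1.2-fold lower number from compound 1 to compound 3 (0.08 log units; within the scatter). Compound 4 `CC(=O)NCC(=O)OCCc1c(-c2ccccc2Cl)c2cc(Cl)ccc2[nH]c1=O` has not yet been measured. It differs from compound 3 in one group: acetamido in place of acetoxy on a saturated chain carbon bound to a carbonyl carbon. Put simply, it has acetamido in place of acetoxy on a saturated chain carbon bound to a carbonyl carbon.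

The closest evidence is a change at that same carbon: no change at the digits printed from compound 2 to compound 3 (within the scatter). The replacements of formyl were also small: a 1.2-fold lower number from compound 1 to compound 2 (0.08 log units; within the scatter), alongside the step to compound 3 already given. None of these steps goes beyond the scatter. However, no measured compound carries acetamido, and three compounds are thin evidence. Even so, no step beyond the scatter is expected in this assay, and no direction is favoured. The expected outcome is no change at the digits printed from compound 3 to compound 4 (within the scatter). For compound 4 the estimated value is 100000 nM, with an estimated range of 55000 nM to 180000 nM.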

Compound 4, half-maximal cytotoxic concentration: 110000 nM
Estimate against measurement, compound 4: 1.1-fold (0.04 log units) below; the range from low to high includes it.
By their numbers in this assay, from the lowest: compounds 2, 3, 4 and 1 (each within the scatter of the next).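

In this assay the step of a 1.1-fold higher number from compound 3 to compound 4 (0.04 log units; within the scatter) shows that this saturated chain carbon bound to a carbonyl carbon can carry a group with a hydrogen-bond donor, as acetamido has one and acetoxy none, without moving the number beyond the scatter. The comparison with cyano at the same carbon, a 1.1-fold higher number from compound 2 to compound 4 (0.04 log units; within the scatter), and the comparison with formyl in place of the whole ester chain, a 1.1-fold lower number from compound 1 to compound 4 (0.04 log units; within the scatter), are also within the scatter, so acetamido joins the groups that leave this reading flat. Nothing available explains why these numbers stay so close.

From the compounds shown here alone, whether an amine or a carboxylic acid at this carbon would behave the same remains open. A longer chain in place of acetamido is also untested by these compounds.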